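A few compounds are considered here, and "the series" means these few. Any claim that something is new, unique, unknown or untested is made for them only; others in the source may bear on it.

Compound 1 `Nc1ncnc2c1nc(O)n2Cc1ccc(Cl)cc1` reaches 10 uM in a functional assay (spleen, spleen) for activation, with Mus musculus as the target; on this read-out higher numbers stand for an effect only at larger amounts of compound and lower numbers for an effect already at smaller amounts. Compound 2 `COc1cccc(Cn2c(O)nc3c(N)ncnc32)c1` gives 10 uM in this assay, level with compound 1 at the digits shown; the gap between them lies within the usual scatter. Compound 3 `Nc1ncnc2c1nc(O)n2Cc1ccccc1` has not yet been measured in this assay. Set against compound 2, compound 3 carries hydrogen in place of methoxy on an aromatic carbon. Within the data shown here, no step between two measured compounds is at hand, so the only footing is that compound 1 and compound 2 sit at the same level. The step expected is no change at the digits printed from compound 2 to compound 3 (within the scatter), none beyond the scatter. Compound 3 is therefore estimated to give 10 uM, between 3 uM and 30 uM.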

Compound 3, minimum effective concentration: 10 uM
Compound 3: the middle estimate sits on the measured number at the digits printed, within the range that was stated.
By their numbers in this assay, from the lowest: compounds 1, 2 and 3 (each within the scatter of the next).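

In this assay, the read-out stays put with the step of no change at the digits printed from compound 2 to compound 3 (within the scatter) on taking hydrogen in place of methoxy, and with the step of no change at the digits printed from compound 1 to compound 3 (within the scatter) on taking hydrogen in place of chloro on an aromatic carbon. Compound 3 thus gives the first reference with hydrogen on the ring, and neither methoxy nor chloro moves the value away from it. No measurement at hand accounts for this sameness. As far as these compounds go, whether an amine or a carboxylic acid on this ring would shift the minimum effective concentration stays open. So does the effect of a longer chain joining the ring to the shared core.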